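The source may report more compounds than this note shows. Statements on the series, on what has been measured and on what is new or still open speak of the compounds shown alone.

Compound 1 `CC(=O)N[C@@H](CSC/C=C(\C)CC/C=C(\C)CCC=C(C)C)C(=O)C=[N+]=[N-]` gives 30300 nM in a functional assay on NALM-6 cells (Homo sapiens); on this read-out higher numbers stand for weaker inhibition and lower numbers for stronger inhibition. Compound 2 `CC(=O)N[C@@H](CSC/C=C(\C)CCC=C(C)C)C(=O)C=[N+]=[N-]` is known in this assay only by a limit, since compound 2 shows > 100000 nM. Compound 2 thus sits at the limit of > 100000 nM in this assay, at which 1 of the 2 values shown sits. Among the numbers shown, compound 2 stands at the weaker end, as the step of an at least 3.3-fold higher number from compound 1 to compound 2 (0.51 log units; beyond the scatter) records.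

Compound 3 `CC(=O)N[C@@H](CSCC=C(C)C)C(=O)C=[N+]=[N-]` differs from compound 2 by hydrogen in place of 3-methylbut-2-en-1-yl on a saturated chain carbon bound to a double-bonded chain carbon, the same kind of change that separates compound 1 from compound 2. Among the compounds with values here, the only measured step that bears on it is an at least 3.3-fold higher number from compound 1 to compound 2 (0.51 log units; beyond the scatter), which moved the number upward past the limit. A further step in the same direction, or at least no return below the limit, is therefore expected, and the estimated step that the limit leaves unreadable from compound 2 to compound 3 reflects this. Compound 3 is expected to give about 300000 nM in this assay, within 100000 nM to 1000000 nM, and most probably as a limit rather than a number.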

Compound 3, half-maximal inhibitory concentration: > 100000 nM
Compound 3: a limit, no number; the forecaster's own chance of this, stated with the estimate: 85%; the middle value lies beyond the limit too.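

In this assay, compound 2 and compound 3 are both known only by a limit, so no step can be read between them. The compounds shown leave open how weak the inhibition by these two compounds really is, and whether hydrogen in place of 3-methylbut-2-en-1-yl changes it here at all.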